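Lengthening the Oxadiazole Side Chain in a Cytotoxicity Series

This account rests on a few compounds, and the source may have more. Where it says the series, first, only, none or still open, it means among the compounds named here.

Compound 2 `CCc1nc(-c2cc(C)c(OCCC(C)CCN3CCN(c4ccnc(N)c4)C3=O)c(C)c2)no1` is the starting point of this step. In an ADME assay on RD cells (Homo sapiens) for cytotoxicity, read by MTT assay, with a stated time of 24 h (a higher number here means that more compound is tolerated, a lower number that less compound is tolerated), compound 2 gives 15700 nM, the lowest of the two numbers that have been measured. Compound 1 `CC(CCOc1ccc(-c2noc(C(F)(F)F)n2)cc1)CCN1CCN(c2ccnc(N)c2)C1=O` is the closest comparison; in this assay compound 1 gives 48100 nM, a higher number. Compound 3 `CC(CCOc1ccc(/C=N/O)cc1)CCN1CCN(c2ccnc(N)c2)C1=O` differs from compound 1 in one group. For compound 3 in this assay the result is a limit of the method, > 100000 nM, not a number. Among the compounds with values here, that exchange gave an at least 2.0-fold higher number from compound 1 to compound 3 (0.31 log units; beyond the scatter), the only measured step here, and its upper end sat at the limit of > 100000 nM in this assay, at which 1 of the 3 values shown sits.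

Compound 4 `CCCc1nc(-c2cc(C)c(OCCC(C)CCN3CCN(c4ccnc(N)c4)C3=O)c(C)c2)no1` differs from compound 2 by methyl in place of hydrogen on a saturated chain carbon, two bonds along the chain from an aromatic carbon. Within the data shown here, no measured step touches this part of the structure: the one known step swaps an entire ring for an open group, whereas this step lengthens an existing chain by a methyl. It therefore gives no guidance on direction, and a change of only a 1.2-fold lower number from compound 2 to compound 4 (0.08 log units; within the scatter) is expected, within the usual scatter. In this assay compound 4 is expected to give about 13000 nM, with a range from 5500 nM to 30000 nM.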

Compound 4, half-maximal cytotoxic concentration: 14100 nM
Beside the measured number, compound 4's estimate is 1.1-fold (0.04 log units) below it, within the range that was stated.
By their numbers in this assay, from the lowest: compounds 4 and 2 (each within the scatter of the next); then compound 1. At a limit, above all of these: compound 3.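

In this assay, lengthening 5-ethyl-1,2,4-oxadiazol-3-yl to 5-propyl-1,2,4-oxadiazol-3-yl gives a 1.1-fold lower number from compound 2 to compound 4 (0.05 log units; within the scatter). Within the data shown here, the one earlier step exchanged a whole ring for an open group, whereas this step is the first to probe the chain on the oxadiazole itself, and at these two lengths the compounds cannot be told apart in this read-out. Nothing among the measurements shown offers an explanation for this result.

Still open, as far as these compounds go, is how a longer chain such as butyl, a branched group such as isopropyl, or a chain ending in an amine or a carboxylic acid would read at this place. Compound 1 and compound 2 differ in more than one place, which leaves trifluoromethyl unjudged against ethyl.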